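A few compounds are considered here, and "the series" means these few. Any claim that something is new, unique, unknown or untested is made for them only; others in the source may bear on it.

Working notes on the series, continued.

Within the data shown here, in an ADME assay on microsomes from liver (Homo sapiens) for metabolic stability, tested at 2.5 uM (a lower number here means slower removal, a higher number faster removal of the compound), compound 1 `O=S(=O)(c1ccc(F)c(F)c1)c1cnc2cc(F)ccc2c1-c1ccc(Cl)cc1` gives 0.01 mL/min, while compound 2 `O=S(=O)(c1ccc(F)c(F)c1)c1cnc2cc(F)ccc2c1-c1cccc(Cl)c1` gives 0.38 mL/min, the highest of the two numbers in hand; the one measured step, a 38-fold higher number from compound 1 to compound 2 (1.58 log units; beyond the scatter), is the only comparison available. Compound 3 `COc1ccc(-c2c(S(=O)(=O)c3ccc(F)c(F)c3)cnc3cc(F)ccc23)cc1` is not yet measured. It differs from compound 2 by 4-methoxyphenyl in place of 3-chlorophenyl on an aromatic carbon. The measured step bears only in part: it shows that altering the substituent on this ring moves this assay strongly, but the new group has not been tried, so its direction is uncertain. Given that compound 1 sits at 0.01 mL/min, a return toward the lower number is thought more likely than a further rise, and a downward step a 3.8-fold lower number from compound 2 to compound 3 (0.58 log units; beyond the scatter) is expected. For compound 3 the estimate in this assay is 0.1 mL/min, within 0.02 mL/min to 0.5 mL/min.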

Compound 3, intrinsic clearance in a liver preparation (reported as CLH), per the amount of preparation that the assay uses: 1.1 mL/min
Beside the measured number, compound 3's estimate is 11-fold (1.04 log units) below it, outside the stated range (above it).
By their numbers in this assay, from the lowest: compound 1; then compound 2; then compound 3.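

In this assay, methoxy in place of chloro gives a 110-fold higher number from compound 1 to compound 3 (2.04 log units; beyond the scatter), so the identity of the group on this ring moves the number strongly, whereas the earlier pair showed only a change in where chloro stands. 4-Methoxyphenyl in place of 3-chlorophenyl gives a 2.9-fold higher number from compound 2 to compound 3 (0.46 log units; beyond the scatter), which places compound 3 highest of the three. Of these groups, only 4-chlorophenyl goes with a low number, so the low number of compound 1 cannot be tied to the ring's substitution pattern alone, and nothing at hand accounts for these differences.

Open, on these data alone, is whether methoxy in place of chloro in 3-chlorophenyl would behave as it does in 4-chlorophenyl. Also open, as far as these compounds go, is what an amine, a carboxylic acid or a longer ether chain in place of methoxy would give in this assay on this ring.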